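A Hydroxyphenyl Swap in a Series Held at a Limit

This account rests on a few compounds, and the source may have more. Where it says the series, first, only, none or still open, it means among the compounds named here.

Measured in a functional assay on MCF7 cells (Homo sapiens) for antiproliferative activity, read by MTT assay, with a stated time of 24 h (on this read-out higher numbers stand for weaker inhibition and lower numbers for stronger inhibition), as limits:
Compound 1 `COc1ccc(-c2noc(-c3ccncc3)n2)cc1OC1CCCC1` gives > 1000000 nM as a limit
Compound 2 `COc1ccc(-c2noc(C3CCCN3)n2)cc1OC1CCCC1` gives > 1000000 nM as a limit
Compound 3 `Fc1ccc(-c2nc(-c3ccccc3)no2)cc1` gives > 1000000 nM as a limit

Compound 2 has only a limit and no true number, and the whole set stands at the limit of > 1000000 nM in this assay, at which 3 of the 3 values shown sit. Compared with compound 2, compound 4 `COc1ccc(-c2noc(-c3ccc(O)cc3)n2)cc1OC1CCCC1` differs in one group: 4-hydroxyphenyl in place of pyrrolidin-2-yl on an aromatic carbon. Among the compounds with values here, the one measured step that bears on this swap is a step that the two limits leave unreadable from compound 1 to compound 2, and it changes a group at the same place, yet its size cannot be read. No step beyond the scatter is therefore expected in this assay, and another limit is the likeliest result. The expected step is a number no higher from compound 2 to compound 4 (the limit leaves the size open). Compound 4 is estimated at 1000000 nM, with an expected range from 100000 nM to 2000000 nM.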

Compound 4, half-maximal inhibitory concentration: 390 nM
Compound 4: middle estimate off by 2600-fold (3.41 log units), on the high side; measured number below the stated range.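

Placing 4-hydroxyphenyl at this position in this assay gives an at least 2500-fold lower number from compound 2 to compound 4 (3.40 log units; beyond the scatter), and likewise an at least 2500-fold lower number from compound 1 to compound 4 (3.40 log units; beyond the scatter). Within the data shown here, both steps are large, so the group here can move the series off its limit to a true number, which the earlier compounds could not show. Pyridin-4-yl is also a six-membered aromatic ring, so such a ring alone is not enough.

Going by these compounds, whether the hydroxyl itself matters stays open. A plain phenyl, 4-methoxyphenyl or 4-aminophenyl at this position would separate its part from that of the ring.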